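Dichloro to monochloro on the fused core

The source may hold more compounds than are shown below. What is called first, only, known or untested is meant among the compounds shown, and "the series" means these compounds.

Two measured compounds frame the question. Compound 1 `ClCc1ccc(Cn2cnc3c(Cl)ncnc32)cc1` in a functional assay on CCRF-CEM cells (Homo sapiens) for cytotoxicity, read by sulforhodamine B assay, with a stated time of 48 h (on this read-out higher numbers stand for weaker inhibition of growth and lower numbers for stronger inhibition of growth), gives 510 nM. Compound 2 `ClCc1ccccc1Cn1cnc2c(Cl)nc(Cl)nc21` in this assay gives 30 nM, the lowest of the two numbers shown; the nearest value is that of compound 1, and the gap between the two lies beyond the scatter. Among the compounds with values here, compound 1 and compound 2 differ in two places at once, so no single step between measured compounds is available.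

Compound 3 `ClCc1ccccc1Cn1cnc2c(Cl)ncnc21` carries the change (hydrogen in place of chloro on an aromatic carbon), hydrogen in place of chloro on an aromatic carbon. Within the data shown here, no measured pair isolates this change, so the size of the step is uncertain; a move toward a higher number in this assay is expected, of moderate size, since compound 1 also lacks this chloro and gives 510 nM. The step from compound 2 is expected as a 5.0-fold higher number from compound 2 to compound 3 (0.70 log units; beyond the scatter). Compound 3 is estimated at 150 nM, within 40 nM to 600 nM.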

Compound 3, concentration for 50% growth inhibition: 1280 nM
Estimate against measurement, compound 3: 8.5-fold (0.93 log units) below; measured number outside the range, above it.
By their numbers in this assay, from the lowest: compound 2; then compound 1; then compound 3.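

In this assay, hydrogen in place of chloro on the aromatic carbon between two ring nitrogen atoms gives a 43-fold higher number from compound 2 to compound 3 (1.63 log units; beyond the scatter), a large step beyond the scatter. This position now has a step of its own. The earlier pair could not provide one, as compound 1 and compound 2 differ in two places at once. With the rest of compound 2 held fixed, the low number goes with the chloro at this carbon, and nothing on hand explains the size of the step.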